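The source may report more compounds than this note shows. Statements on the series, on what has been measured and on what is new or still open speak of the compounds shown alone.

Working notes on the cinnamamide series, all three measured members sharing one core and differing only in the group on the amide nitrogen. Compound 1 `COc1ccc2c(=O)c(/C=C/C(=O)Nc3ccc(C)cc3)coc2c1` gives 39300 nM in a functional assay (QGY7701 cells, Homo sapiens) for inhibition, read by MTT assay, with a stated time of 48 h; a lower number here means a stronger inhibitor, a higher number a weaker inhibitor. Compound 2 `COc1ccc2c(=O)c(/C=C/C(=O)Nc3ccccc3)coc2c1` gives 14000 nM, and compound 3 `COc1ccc(CNC(=O)/C=C/c2coc3cc(OC)ccc3c2=O)cc1` gives 15700 nM. Compound 3 thus stands second highest of the three numbers, close to compound 2 and furthest from compound 1.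

Compound 4 `COc1ccc2c(=O)c(/C=C/C(=O)NCc3ccccc3F)coc2c1` is not yet measured. Its difference from compound 3: 2-fluorophenyl in place of 4-methoxyphenyl on a saturated chain carbon bound to an amide-type nitrogen. Among the compounds with values here, two measured steps bear on this kind of change at the amide nitrogen: a 2.5-fold lower number from compound 1 to compound 3 (0.40 log units; beyond the scatter), and a 1.1-fold higher number from compound 2 to compound 3 (0.05 log units; within the scatter). Both concern the whole group on the nitrogen, and neither swaps one substituent on a benzyl ring for another, so the guidance is thin. Given the nearly flat step between compound 2 and compound 3, no step beyond the scatter is expected in this assay for compound 4. Compound 4 is therefore estimated at 15000 nM, within 6000 nM to 40000 nM. This expected outcome corresponds to a 1.0-fold lower number from compound 3 to compound 4 (0.02 log units; within the scatter).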

Compound 4, half-maximal inhibitory concentration: 34000 nM
The estimate for compound 4 lay 2.3-fold (0.36 log units) below the measured number; low and high end bracket the measured number.
By their numbers in this assay, from the lowest: compounds 2 and 3 (each within the scatter of the next); then compounds 4 and 1 (each within the scatter of the next).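

Swapping one substituted benzyl group for another on the amide-type nitrogen is not neutral in this assay: a 2.2-fold higher number from compound 3 to compound 4 (0.34 log units; beyond the scatter) is the first step in the series that keeps the benzyl link and changes only the ring, so the flat step from the phenyl to the 4-methoxybenzyl amide does not hold for every benzyl group. The 2-fluorobenzyl group also gives a 2.4-fold higher number from compound 2 to compound 4 (0.39 log units; beyond the scatter) and sits within the scatter of the 4-methylphenyl amide, with a 1.2-fold lower number from compound 1 to compound 4 (0.06 log units; within the scatter) as the step, so a benzyl link alone does not secure the level of compound 3. Nothing shown gives a measured reason for these steps.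

On these data alone, whether the loss of 4-methoxy or the entry of 2-fluoro carries the step remains open, since both change at once. A plain benzyl group, or a benzyl ring bearing an amine or a carboxylic acid, would test how far this position tolerates change.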